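A few compounds are considered here, and "the series" means these few. Any claim that something is new, unique, unknown or untested is made for them only; others in the source may bear on it.

In a functional assay on HepG2 cells (Homo sapiens) for cytotoxicity, read by MTT assay, with a stated time of 72 h (a lower number here means a stronger inhibitor of growth, a higher number a weaker inhibitor of growth), three compounds of a shared core have been measured. Compound 2, `C[Se]/C(=N\C(=O)c1cccs1)NC(=O)c1cccs1`, gives 1500 nM in this assay, the lowest of the two numbers recorded. Compound 3, `O=C(/N=C(/NC(=O)c1ccno1)[Se]Cc1ccccc1)c1ccno1`, gives 58900 nM in this assay, a gap from compound 2 that lies beyond the usual scatter. Compound 1, `CS/C(=N\C(=O)c1sccc1Cl)NC(=O)c1sccc1Cl`, reaches only a limit of this assay, > 100000 nM, and no number.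

Compound 4, `CS/C(=N\C(=O)c1cccs1)NC(=O)c1cccs1`, has not yet been measured. It differs from compound 2 in a single place: a group of 2 heavy atoms (1 carbon, 1 sulfur; no ring) in place of a group of 2 heavy atoms (1 carbon, 1 selenium; no ring), on a carbon with a double bond to nitrogen. Going by the values given here, no pair of measured compounds isolates this exchange, so its size can only be guessed. What can be said is that compound 1 also carries methylsulfanyl on the carbon with a double bond to nitrogen, while its two ring ends differ from those of compound 4, and compound 1 shows only a limit in this assay. The step from compound 2 to compound 4 is therefore expected to run toward a higher number, a weaker inhibitor of growth, by about a 20-fold higher number from compound 2 to compound 4 (1.30 log units; beyond the scatter), with wide uncertainty. Compound 4 is estimated at 30000 nM, within a range from 5000 nM to 100000 nM. A limit reading rather than a number is also a real possibility for compound 4.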

Compound 4, concentration for total growth inhibition: > 100000 nM
Compound 4: a limit, no number (the forecaster's own chance of this, stated with the estimate: 35%); middle value at least 3.3-fold (0.52 log units) away from the limit.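

Holding everything else fixed, this pair isolates one exchange for the first time: methylsulfanyl replaces the selenium-bearing group on a carbon with a double bond to nitrogen, and in this assay this gives an at least 66-fold higher number from compound 2 to compound 4 (1.82 log units; beyond the scatter). Compound 4 reads as a limit and not a number, the same limit reached by compound 1, so the step sets only a lower bound on the size of the exchange: the limit of > 100000 nM in this assay, at which 2 of the 4 values shown sit.

Compound 1 also carries methylsulfanyl, but its ring ends differ from those of compound 2, so it could not separate the two changes; this pair shows that the exchange alone, with the ring ends unchanged, is enough to produce a large step.

The compounds shown leave open whether the exchange has a similar size with other ring ends, since this single pair is the only direct comparison. They also leave open how an ethyl group on selenium, a longer chain on selenium or a methoxy group on the same carbon would read in this assay, and they do not explain why the exchange has so large an effect.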